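The source may hold more compounds than are shown below. What is called first, only, known or untested is meant among the compounds shown, and "the series" means these compounds.

Measured compounds:

Compound 1, `C=C[C@@](C)(/C=C/c1ccc(O)c(/C=C/c2ccc(F)cc2)c1)CCC=C(C)C`, in a functional assay on Raji cells (Homo sapiens) for cytotoxicity, with a stated time of 72 h (on this read-out lower numbers stand for an effect already at smaller amounts and higher numbers for an effect only at larger amounts of compound), gives > 26000 nM, which is a limit of the assay and not a number.
Compound 2, `C=C[C@@](C)(/C=C/c1ccc(O)c(/C=C/c2ccc(Cl)cc2)c1)CCC=C(C)C`, in this assay gives > 26000 nM, also a limit of the assay.
Compound 3, `CC(C)=CCC[C@](C)(/C=C/c1ccc(O)cc1)/C=C/c1cccc(F)c1`, in this assay gives > 26000 nM, again a limit of the assay.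

All three measured values sit at the same limit, (the limit of > 26000 nM in this assay, at which 3 of the 3 values shown sit). The change from compound 1 to compound 2 is chloro in place of fluoro on an aromatic carbon, and the step it made is a step that the two limits leave unreadable from compound 1 to compound 2. Nothing more can be read from that pair than that both stay at the limit.

Compound 3 differs from compound 1 in more than one place; the difference between the two cores is not broken down here. Compound 4, `CC(C)=CCC[C@](C)(/C=C/c1ccc(O)cc1)/C=C/c1cccc(Cl)c1`, has not been measured in this assay. It differs from compound 3 by chloro in place of fluoro on an aromatic carbon. This is the same kind of change as from compound 1 to compound 2, but not the same: there the chlorine sits para to a large group, here meta to a large group.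

The expectation for compound 4 rests on compound 3, whose value > 26000 nM is a limit, and on the pair compound 1 to compound 2, which stayed at the limit under the same kind of change. The step from compound 3 to compound 4 is therefore expected to be a step that the limit leaves unreadable from compound 3 to compound 4, with compound 4 most likely reported as a limit as well. The estimate for compound 4 in this assay is 40000 nM, within a range from 15000 nM to 150000 nM.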

Compound 4, half-maximal effective concentration: > 26000 nM
Compound 4 was reported as a limit; the forecaster's own chance of this, stated with the estimate: 85%; the middle value is on the limit's open side.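

No new step can be read: compound 3 and compound 4 both stay at a limit, so chloro in place of fluoro gives no readable size between them. The series stands as follows: the limit of > 26000 nM in this assay, at which 4 of the 4 values shown sit. The compounds shown leave open where the real values of compound 1, compound 2, compound 3 and compound 4 lie in this assay, and whether either halogen exchange changes anything there.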